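A few compounds are considered here, and "the series" means these few. Any claim that something is new, unique, unknown or untested is made for them only; others in the source may bear on it.

Measured compounds in a functional assay on HEK293 cells for agonist activity at G-protein coupled receptor 39 (Mus musculus), read by inositol phosphate accumulation; on this read-out higher numbers stand for an effect only at larger amounts of compound and lower numbers for an effect already at smaller amounts:
compound 1 `CNc1nc(NCC(C)(C)C)cc(-c2ccccn2)n1` gives 365 nM
compound 2 `CNc1nc(NCc2ccc(Cl)cc2Cl)cc(-c2ccccn2)n1` gives 0.5 nM
compound 3 `CNc1nc(NCc2ccc(Cl)cc2)cc(-c2ccccn2)n1` gives 3 nM

Among these three, compound 3 holds the middle position: the step of a 6.0-fold higher number from compound 2 to compound 3 (0.78 log units; beyond the scatter) separates it from compound 2, and the step of a 120-fold lower number from compound 1 to compound 3 (2.09 log units; beyond the scatter) separates it from compound 1, both beyond the scatter.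

Compound 4 `CNc1nc(NCC2CCCCC2)cc(-c2ccccn2)n1` arises from compound 3 by the change (cyclohexyl in place of 4-chlorophenyl on a saturated chain carbon bound to a nitrogen on an aromatic ring). Within the data shown here, two measured steps bear on it. The step of a 120-fold lower number from compound 1 to compound 3 (2.09 log units; beyond the scatter) shows that putting a 4-chlorophenyl where tert-butyl stood lowered the number greatly; the step of a 6.0-fold higher number from compound 2 to compound 3 (0.78 log units; beyond the scatter) shows that removing a chloro alone raised it modestly. Compound 4 gives up both the chloro and the six-membered aromatic ring, keeping a ring of carbon only, so the expectation is a move back toward compound 1, a large rise in this assay rather than none, though perhaps not all the way, since compound 1 carries no ring at all. The expected step is a 33-fold higher number from compound 3 to compound 4 (1.52 log units; beyond the scatter). For compound 4 the estimated value in this assay is 100 nM, expected to lie between 20 nM and 600 nM.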

Compound 4, half-maximal effective concentration: 10 nM
Beside the measured number, compound 4's estimate is 10-fold (1.00 log units) above it; the measured number lies below the stated range.
By their numbers in this assay, from the lowest: compound 2; then compound 3; then compound 4; then compound 1.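

In this assay, replacing the 4-chlorophenyl with a non-aromatic ring of carbon only costs little, as a 3.3-fold higher number from compound 3 to compound 4 (0.52 log units; beyond the scatter) is a modest step, while a 37-fold lower number from compound 1 to compound 4 (1.56 log units; beyond the scatter) is a large one, so among these compounds an aromatic ring at this place is not needed for most of the drop from the tert-butyl compound. The 2,4-dichlorophenyl still stands clearly apart, since a 20-fold higher number from compound 2 to compound 4 (1.30 log units; beyond the scatter) is also large. Nothing measured here explains why cyclohexyl comes so close to 4-chlorophenyl.

The compounds shown leave open where an unsubstituted phenyl would fall, so the separate shares of the chloro and of the aromatic ring in the step from compound 3 to compound 4 remain unresolved. They also leave open whether a piperidine ring, with its amine nitrogen, or a longer chain would be tolerated at this place.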